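Fluoro for hydrogen: a small cytotoxicity series

A few compounds are considered here, and "the series" means these few. Any claim that something is new, unique, unknown or untested is made for them only; others in the source may bear on it.

Compound 1, `S=C(Nc1ccc(Cl)cc1)Nc1nc2ccccc2s1`, gives 39000 nM in a functional assay on THP-1 cells (Homo sapiens) for cytotoxicity, read by MTT assay, with a stated time of 48 h; a lower number here means a stronger inhibitor, a higher number a weaker inhibitor.
Compound 2, `Fc1ccc2nc(NC(=S)Nc3ccc(Cl)cc3)sc2c1`, gives 31200 nM in this assay.
Compound 3, `S=C(Nc1ccccc1)Nc1nc2c(Cl)cccc2s1`, gives 31800 nM in this assay.

All three measured numbers lie within the scatter of one another, so none of them can be set apart as stronger or weaker. Compound 3 has the same atoms as compound 1, joined differently; the difference between the two cores is not broken down here. Compound 1 and compound 2 differ in one place, (fluoro in place of hydrogen on an aromatic carbon), and the step is a 1.3-fold lower number from compound 1 to compound 2 (0.10 log units; within the scatter).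

Compound 4, `Fc1ccc(NC(=S)Nc2nc3c(Cl)cccc3s2)cc1`, is not yet measured. It differs from compound 3 by fluoro in place of hydrogen on an aromatic carbon. Going by the values given here, this is the same kind of change as the one from compound 1 to compound 2, but the surroundings differ: in the earlier pair the fluoro enters a ring that is part of a fused or bridged system of two rings, meta to a fused ring and para to a fused ring, whereas in compound 4 it enters a six-membered aromatic ring of carbon only, para to a large group. Among the compounds with values here, with only one earlier instance of this change, and that one within the scatter, the expectation for compound 4 rests on the step from compound 1 to compound 2 alone. The step from compound 3 to compound 4 is expected to be a 1.1-fold lower number from compound 3 to compound 4 (0.06 log units; within the scatter), set beside the measured 1.3-fold lower number from compound 1 to compound 2 (0.10 log units; within the scatter). Compound 4 is therefore estimated at 28000 nM, with a range from 14000 nM to 56000 nM.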

Compound 4, half-maximal inhibitory concentration: > 50000 nM
Compound 4: only a limit was reported; the forecaster's own chance of this, stated with the estimate: 5%; middle value at least 1.7-fold (0.25 log units) from the limit.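

In this assay compound 4 is reported only as a limit, > 50000 nM. The change from phenyl to 4-fluorophenyl therefore reads as a floor, an at least 1.5-fold higher number from compound 3 to compound 4 (0.19 log units; that floor lies within the scatter), and that floor itself lies within the scatter. This does not show that fluoro in place of hydrogen carries over from one core to another with the same result, nor does it show that the result depends on the core, as the two instances also place the fluoro on different rings and the comparison remains undecided: the same change on two cores in this assay, a 1.3-fold lower number (0.10 log units; within the scatter) from compound 1 to compound 2 and an at least 1.5-fold higher number (0.19 log units; that floor lies within the scatter) from compound 3 to compound 4; the limit leaves it open whether they differ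

Going by these compounds alone, the true size of the step on the core of compound 3 stays open, as does any real difference between the two instances, with only one compound resting on the limit: the limit of > 50000 nM in this assay, at which 1 of the 4 values shown sits. Also open is whether a group other than fluoro on the same aromatic carbon, such as an amine, a carboxylic acid or a longer chain, would give a number beyond the scatter on either core.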